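Swapping Phenyl for Pyridin-3-yl on a Weak Sulfonamide

This account rests on a few compounds, and the source may have more. Where it says the series, first, only, none or still open, it means among the compounds named here.

Compound 1, `O=C(O)CSc1nnc(Br)n1Cc1ccc(Br)c2ccccc12`: 94 nM
Compound 2, `O=C(CSc1nnc(Br)n1Cc1ccc(Br)c2ccccc12)NO`: 640 nM
Compound 3, `O=S(=O)(CSc1nnc(Br)n1Cc1ccc(Br)c2ccccc12)Nc1ccccc1`: 15800 nM

These three compounds share one core and differ only in the group on the saturated chain carbon bound to sulfur. In an assay on HEK293 cells for inhibition of solute carrier family 22 member 12 (Homo sapiens) (on this read-out higher numbers stand for weaker inhibition and lower numbers for stronger inhibition), compound 3 gives 15800 nM, the highest of the three numbers. Its gaps to the others are a 170-fold higher number from compound 1 to compound 3 (2.23 log units; beyond the scatter) and a 25-fold higher number from compound 2 to compound 3 (1.39 log units; beyond the scatter), both beyond the scatter. Compound 4 `O=S(=O)(CSc1nnc(Br)n1Cc1ccc(Br)c2ccccc12)Nc1cccnc1` keeps the sulfonamide of compound 3 and changes only (pyridin-3-yl in place of phenyl on a sulfonamide nitrogen). Within the data shown here, none of the measured steps alters the ring on the sulfonamide nitrogen; all three swap the group at the chain end, so no step speaks directly to this change. With nothing comparable to lean on, compound 4 is expected to stay near compound 3, a step of a 1.1-fold lower number from compound 3 to compound 4 (0.02 log units; within the scatter) that is not beyond the scatter. The estimate for compound 4 is 15000 nM, within 5000 nM to 45000 nM.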

Compound 4, half-maximal inhibitory concentration: 32 nM
Beside the measured number, compound 4's estimate is 470-fold (2.67 log units) above it; the whole stated range lies above it.
By their numbers in this assay, from the lowest: compound 4; then compound 1; then compound 2; then compound 3.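

In this assay, the ring on a sulfonamide nitrogen proves decisive: pyridin-3-yl in place of phenyl gives a very large gain (a 490-fold lower number from compound 3 to compound 4 (2.69 log units; beyond the scatter)). A sulfonamide at the chain end is therefore not weak in itself, since with this ring it outperforms both the hydroxycarbamoyl group (a 20-fold lower number from compound 2 to compound 4 (1.30 log units; beyond the scatter)) and the carboxy group (a 2.9-fold lower number from compound 1 to compound 4 (0.47 log units; beyond the scatter)). Nothing measured here explains why this single ring change has so large an effect. Going by these compounds, whether pyridin-4-yl or pyridin-2-yl on the sulfonamide nitrogen would perform like pyridin-3-yl remains open.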